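Lengthening the Acid Chain of Compound 2

A few compounds are considered here, and "the series" means these few. Any claim that something is new, unique, unknown or untested is made for them only; others in the source may bear on it.

Among the measured compounds shown here, compound 2 `O=C(O)CCCCOc1cc(-c2ccccc2)cc(-c2ccccc2)n1` gives the highest number among the three measured members of this set in an assay for binding affinity to leukotriene B4 receptor 1 (Homo sapiens) (on this read-out lower numbers stand for stronger inhibition and higher numbers for weaker inhibition), at 300 nM. The other two sit well below it: compound 1 `CC(CCCCOc1cc(-c2ccccc2)cc(-c2ccccc2F)n1)C(=O)O` gives 18 nM and compound 3 `O=C(O)CCCCCCOc1cc(-c2ccccc2)cc(-c2ccccc2)n1` gives 15 nM. Compound 4 `CC(C)(CCCCCCOc1cc(-c2ccccc2)cc(-c2ccccc2)n1)C(=O)O` differs from compound 2 by 3-carboxy-3-methylbutyl in place of carboxy on a saturated chain carbon, four bonds along the chain from an oxygen on an aromatic ring. For the measured compounds named here, the measured step that bears on this change is the one from compound 2 to compound 3, a 20-fold lower number from compound 2 to compound 3 (1.30 log units; beyond the scatter), in which carboxy became 2-carboxyethyl without methyl branching. Going by the values given here, compound 4 carries that same lengthening and in addition the methyl branching at the carbon bearing the acid; no measured pair varies that branching alone, so its contribution cannot be read from these numbers. Compound 1 combines a single methyl with a shorter chain and another aryl and gives no clean comparison. The expected step from compound 2 to compound 4 is therefore of about the size seen from compound 2 to compound 3, downward, a 15-fold lower number from compound 2 to compound 4 (1.18 log units; beyond the scatter). The estimate for compound 4 is 20 nM, within 5 nM to 80 nM.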

Compound 4, half-maximal inhibitory concentration: 60 nM
Compound 4: middle estimate off by 3.0-fold (0.48 log units), on the low side; the range from low to high includes it.
By their numbers in this assay, from the lowest: compounds 3 and 1 (each within the scatter of the next); then compound 4; then compound 2.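

In this assay, putting 1-carboxy-1-methylethyl in place of carboxy, six bonds along the chain from an oxygen on an aromatic ring, gives a 4.0-fold higher number from compound 3 to compound 4 (0.60 log units; beyond the scatter), so the methyl branching at the carbon bearing the acid now has a measured step of its own and it runs upward. The lengthened, branched chain still keeps part of the gain over the short acid, with a 5.0-fold lower number from compound 2 to compound 4 (0.70 log units; beyond the scatter), a smaller step than a 20-fold lower number from compound 2 to compound 3 (1.30 log units; beyond the scatter). No measurement at hand gives a reason for this loss.

On these data alone, how a single methyl at that carbon would behave on the longer chain remains open, since compound 1 differs from the others in more than one place. Also open, as far as these compounds go, is how a still longer chain, or a tetrazole in place of the carboxylic acid, would read in this assay.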